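Methoxy to fluoro on the aryl group: working notes

This account rests on a few compounds, and the source may have more. Where it says the series, first, only, none or still open, it means among the compounds named here.

Compound 1 `CCn1c(-c2ccccc2)nc2c(NC3CCCC3)ncnc21`: 5790 nM
Compound 2 `COc1ccc(-c2nc3c(NC4CCCC4)ncnc3n2C)cc1`: > 30000 nM
Compound 3 `CCCn1c(-c2ccccc2)nc2c(N)ncnc21`: 1040 nM

In a functional assay on CHO cells for antagonist activity at adenosine receptor A2b (Homo sapiens), read by 33P incorporation, with a stated time of 20 min (on this read-out lower numbers stand for stronger inhibition and higher numbers for weaker inhibition), compound 1 gives 5790 nM and compound 3 gives 1040 nM. For compound 2 only a limit is known, > 30000 nM, so compound 2 sits at the limit of > 30000 nM in this assay, at which 1 of the 3 values shown sits, and no number places it among the others. Compound 4 `Cn1c(-c2ccc(F)cc2)nc2c(NC3CCCC3)ncnc21` differs from compound 2 by fluoro in place of methoxy on an aromatic carbon. Going by the values given here, no pair of measured compounds shows this change, so its size is uncertain; a step toward stronger inhibition, of moderate size, is expected, but the limit for compound 2 leaves its true size open. Compound 4 is expected near 15000 nM in this assay, with a range from 4000 nM to 60000 nM. The expected step is an at least 2.0-fold lower number from compound 2 to compound 4 (0.30 log units; that floor lies within the scatter).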

Compound 4, inhibition constant: > 30000 nM
Compound 4: no number, only a limit; the forecaster's own chance of this, stated with the estimate: 40%; at least 2.0-fold (0.30 log units) between middle value and limit.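

Compound 2 and compound 4 each carry only a limit, and no step can be read between them. The compounds shown leave open what change in inhibition, if any, 4-methoxyphenyl to 4-fluorophenyl brings.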